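Propyl to butyl on a well-tolerated compound

A few compounds are considered here, and "the series" means these few. Any claim that something is new, unique, unknown or untested is made for them only; others in the source may bear on it.

The three measured compounds sharing one core set the scene in a toxicity assay on THP-1 cells (Homo sapiens) for inhibition (a higher number here means that more compound is tolerated, a lower number that less compound is tolerated), and none of them gives an actual number. Compound 1 (`COc1ccc(-c2cnc(NC(=O)c3cccc([N+](=O)[O-])c3)n2C)cc1`) reads > 100000 nM, which is a limit and not a number. Compound 2 (`COc1ccc(-c2cnc(NC(=O)CCc3ccccc3)n2C)cc1`) reads > 100000 nM, again a limit. Compound 3 (`CCCn1c(-c2ccc(OC)cc2)cnc1NC(=O)c1ccc(F)cc1`) reads > 100000 nM, also a limit and not a number. So compound 3 stands exactly where the other two stand, as the summary of the data shows (the limit of > 100000 nM in this assay, at which 3 of the 3 values shown sit).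

Compound 4 (`CCCCn1c(-c2ccc(OC)cc2)cnc1NC(=O)c1ccc(F)cc1`) differs from compound 3 in one place (methyl in place of hydrogen on a saturated chain carbon, three bonds along the chain from an aromatic nitrogen). It carries methyl in place of hydrogen on a saturated chain carbon, three bonds along the chain from an aromatic nitrogen, which makes propyl into butyl. For the measured compounds named here, no two measured compounds differ in only one place, so no measured step shows how large such a change might be. The nearest guide is compound 3 at > 100000 nM, and that guide is itself a limit. The expected change (a number no higher from compound 3 to compound 4 (the limit leaves the size open)) stays within the usual scatter, with no direction favoured. For compound 4 the estimated value is 100000 nM, with an expected range from 50000 nM to 200000 nM, and a further limit rather than a number is the likeliest report.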

Compound 4, half-maximal cytotoxic concentration: > 100000 nM
Compound 4 was reported as a limit; the forecaster's own chance of this, stated with the estimate: 85%; the middle value sits exactly at the limit.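

For the compounds shown here, compound 3 and compound 4 both report a limit rather than a number, so the change from propyl to butyl gives no step whose size can be read in this assay. The compounds shown leave open what concentration actually harms these cells, and whether any change to the shared core would give a real number, since every result so far stops at the same point: the limit of > 100000 nM in this assay, at which 4 of the 4 values shown sit.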